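The source may report more compounds than this note shows. Statements on the series, on what has been measured and on what is new or still open speak of the compounds shown alone.

Compound 1 `CC(=O)/C(=N\c1ccc(Cl)cc1)NNc1ccccc1C`, compound 2 `CC(=O)/C(=N\c1ccc(Cl)cc1)NNc1ccccc1Cl` and compound 3 `CC(=O)/C(=N\c1ccc(Cl)cc1)NNc1ccccc1C(F)(F)F` share one core and differ only in the group carried on the second aromatic ring. In an assay on isolated protein for binding affinity to corticotropin-releasing factor receptor 1 (Homo sapiens) (a lower number here means a stronger inhibitor, a higher number a weaker inhibitor), compound 1 gives 1830 nM, and compound 2 gives 3870 nM. For compound 3 the result is a limit rather than a number, > 10000 nM. Compound 3 thus stands at the weak end of the three, sitting at the limit of > 10000 nM in this assay, at which 1 of the 3 values shown sits. The measured steps all run one way: a 2.1-fold higher number from compound 1 to compound 2 (0.33 log units; beyond the scatter), an at least 5.4-fold higher number from compound 1 to compound 3 (0.73 log units; beyond the scatter) and an at least 2.5-fold higher number from compound 2 to compound 3 (0.41 log units; beyond the scatter). Compound 4 `CC(=O)/C(=N\c1ccc(Cl)cc1)NNc1ccccc1` follows the step from compound 3 in which (hydrogen in place of trifluoromethyl on an aromatic carbon). Among the compounds with values here, none of the measured steps removes a group altogether, but the sequence from methyl through chloro to trifluoromethyl raised the number at every step, so the reverse move to hydrogen is expected to lower it, by about an at least 3.3-fold lower number from compound 3 to compound 4 (0.52 log units; beyond the scatter), the direction being firmer than the size. Compound 4 is therefore estimated to give about 3000 nM in this assay, within a range from 1000 nM to 10000 nM.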

Compound 4, inhibition constant: > 10000 nM
Compound 4 gave a limit, no number (the forecaster's own chance of this, stated with the estimate: 20%); middle value at least 3.3-fold (0.52 log units) away from the limit.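

In this assay compound 4, which carries hydrogen on this aromatic carbon, gives a limit of the assay and not a number (> 10000 nM). Removing the group therefore does not bring the lower number that the earlier series pointed to: hydrogen in place of chloro gives an at least 2.5-fold higher number from compound 2 to compound 4 (0.41 log units; beyond the scatter) and hydrogen in place of methyl gives an at least 5.4-fold higher number from compound 1 to compound 4 (0.73 log units; beyond the scatter), so at this position compound 1 and compound 2, with methyl and chloro, both read lower than the unsubstituted compound 4, and hydrogen does not continue the earlier order. Whether hydrogen or trifluoromethyl is the poorer group here cannot be read, because both compounds stand at the limit: the limit of > 10000 nM in this assay, at which 2 of the 4 values shown sit.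

The compounds shown leave open how far a group on this carbon can lower the number, since the best value here remains that of compound 1 (1830 nM), and whether an ethyl group, a methoxy group or an amine would go below it. They also leave open whether the fluoro group, smaller than trifluoromethyl by name and atoms, would read nearer to methyl or to hydrogen.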